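The source may report more compounds than this note shows. Statements on the series, on what has been measured and on what is new or still open speak of the compounds shown alone.

Measured so far:
- Compound 1 `COc1ccc(-c2cn(-c3cc(OC)c(OC)c(OC)c3)nn2)cc1`: > 10000 nM
- Compound 2 `COc1ccc(-c2cn(-c3cc(OC)c(OC)c(OC)c3)nn2)cc1O`: > 10000 nM

In a functional assay on K562 cells (Homo sapiens) for cytotoxicity, read by MTT assay, with a stated time of 5 days (a higher number here means a weaker inhibitor, a lower number a stronger inhibitor), compound 2 gives > 10000 nM, which is a limit of the assay and not a number. Compound 1 shares this position, as the limit of > 10000 nM in this assay, at which 2 of the 2 values shown sit, shows. Compound 3 `COc1ccc(-c2cn(-c3cc(OC)c(OC)c(OC)c3)nn2)cc1[N+](=O)[O-]` carries one change from compound 2: nitro in place of hydroxy on an aromatic carbon. A nitro group replaces the hydroxy group, on an aromatic carbon ortho to a methoxy group. Going by the values given here, the one measured step that bears on this is a step that the two limits leave unreadable from compound 1 to compound 2. It touches the same aromatic carbon, but it has no readable size to carry over. No step beyond the usual scatter can therefore be predicted in this assay, in either direction, and compound 3 will most likely report the same limit. The expected step is a number no higher from compound 2 to compound 3 (the limit leaves the size open). For compound 3 the estimated value is 10000 nM, with an expected range of 3000 nM to 20000 nM.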

Compound 3, half-maximal inhibitory concentration: > 10000 nM
Compound 3: a limit, no number (the forecaster's own chance of this, stated with the estimate: 75%); the middle value sits exactly at the limit.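

Going by these compounds alone, compound 3 also gives a limit of the assay and not a number, so no step among compound 1, compound 2 and compound 3 can be read: the limit of > 10000 nM in this assay, at which 3 of the 3 values shown sit.

On these data alone, how far each compound lies past that limit, and whether hydrogen, hydroxy or nitro on this aromatic carbon changes potency in this assay, stays open.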